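A few compounds are considered here, and "the series" means these few. Any claim that something is new, unique, unknown or untested is made for them only; others in the source may bear on it.

Among the measured compounds shown here, in a functional assay on K562 cells (Homo sapiens) for inhibition (a higher number here means a weaker inhibitor, a lower number a stronger inhibitor), compound 1 `CCOc1ccc(Br)cc1-c1cc(Nc2cccc(C#N)c2)nc(N)n1` gives 350 nM, the higher of the two numbers so far and beyond the scatter from compound 2 `Cc1ccc(Br)cc1-c1cc(Nc2ccc(Br)cc2)nc(N)n1`, which gives 70 nM. Compound 3 `CCOc1ccc(Br)cc1-c1cc(Nc2ccc(Cl)cc2)nc(N)n1` departs from compound 1 in one place, with 4-chlorophenyl in place of 3-cyanophenyl on a nitrogen on an aromatic ring. For the measured compounds named here, no measured pair isolates this change. Going by the values given here, the only guide is compound 2 at 70 nM, which also carries no nitrile. A move to a lower number is expected in this assay, estimated as a 2.7-fold lower number from compound 1 to compound 3 (0.43 log units; beyond the scatter). Compound 3 is expected at 130 nM, with an estimated range of 45 nM to 350 nM.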

Compound 3, half-maximal inhibitory concentration: 50 nM
The estimate for compound 3 lay 2.6-fold (0.41 log units) above the measured number, within the range that was stated.
By their numbers in this assay, from the lowest: compounds 3 and 2 (each within the scatter of the next); then compound 1.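

Among the compounds shown here, compound 1 and compound 3 give the first single-place comparison: on a nitrogen on an aromatic ring, 4-chlorophenyl in place of 3-cyanophenyl gives a 7.0-fold lower number from compound 1 to compound 3 (0.85 log units; beyond the scatter) in this assay. The aryl group at this position can therefore move the number beyond the scatter with the rest of compound 1 unchanged. Nothing available accounts for the size of this step. The compounds shown leave open whether the step follows from gaining the chlorine, losing the nitrile, or the changed ring position. As far as these compounds go, how a 4-methoxyphenyl or a 4-aminophenyl group would read at this position also remains open.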